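This account rests on a few compounds, and the source may have more. Where it says the series, first, only, none or still open, it means among the compounds named here.

Measured in a functional assay on the whole organism with Mus musculus as the target, in the maximal electroshock model, at a dose of 50 mg/kg by the oral route; a higher number here means more inhibition at the dose given (going by the name of the read-out), a lower number less inhibition:
compound 1 `C(=C/c1ccccc1OCCCCN1CCCCC1)\c1ccccc1` gives 42.9%
compound 2 `OC1CCN(CCCCOc2ccccc2/C=C/c2ccccc2)CC1` gives 0%
compound 3 `OCC1CCCN(CCCCOc2ccccc2/C=C/c2ccccc2)C1` gives 12.5%

Compound 3 stands second highest of the three numbers: a number 30.4 percentage points lower from compound 1 to compound 3 (beyond the scatter) leaves it well under compound 1, while a number 12.5 percentage points higher from compound 2 to compound 3 (beyond the scatter) puts it above compound 2, which shows no inhibition at all. Compound 4 `O=C(O)C1CCCN(CCCCOc2ccccc2/C=C/c2ccccc2)C1` is not yet measured in this assay. (carboxy in place of hydroxymethyl on a saturated ring carbon). Among the measured compounds shown here, no measured step exchanges these two groups, so the bearing steps are indirect. a number 42.9 percentage points lower from compound 1 to compound 2 (beyond the scatter) and a number 30.4 percentage points lower from compound 1 to compound 3 (beyond the scatter) show that putting either a hydroxy or a hydroxymethyl onto the saturated ring cut inhibition strongly, and a number 12.5 percentage points higher from compound 2 to compound 3 (beyond the scatter) shows that the hydroxymethyl version kept a modest amount of inhibition where the hydroxy version kept none. The carboxy group is a third oxygen-bearing group at the same ring carbon; the expectation is therefore a further step downward, toward the floor already seen for compound 2, though with wide uncertainty. Compound 4 is expected at 5%, range 0% to 25%. The expected step is a number 7.5 percentage points lower from compound 3 to compound 4 (within the scatter).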

Compound 4, a percentage reported as inhibition, in the whole organism at one dose (the size of the read-out at that dose, not a potency): 12.5%
Beside the measured number, compound 4's estimate is 7.5 percentage points below it; the measured number falls inside the stated range.
By their numbers in this assay, from the lowest: compound 2; then compounds 3 and 4 (each within the scatter of the next); then compound 1.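

At the ring carbon two ring bonds from the ring nitrogen, this assay does not separate carboxy from hydroxymethyl (no change at the digits printed from compound 3 to compound 4 (within the scatter)). Carboxy in place of hydrogen there still costs a large part of the inhibition (a number 30.4 percentage points lower from compound 1 to compound 4 (beyond the scatter)), while the 3-carboxypiperidin-1-yl compound keeps a modest margin over the 4-hydroxypiperidin-1-yl compound (a number 12.5 percentage points higher from compound 2 to compound 4 (beyond the scatter)). Nothing on hand accounts for carboxy and hydroxymethyl reading alike at this position.

Open, going by these compounds, is whether a methyl ester or a primary amide on this ring carbon would read like carboxy and hydroxymethyl, or whether a plain methyl there would come closer to compound 1. Also open, on these data alone, is how carboxy would read on the ring carbon that bears the hydroxy in compound 2, since ring position and group change together between compound 2 and compound 4.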